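A few compounds are considered here, and "the series" means these few. Any claim that something is new, unique, unknown or untested is made for them only; others in the source may bear on it.

Compound 2 `N#CC1=C(N)N(c2ccc(S(N)(=O)=O)cc2)C2=C(CCCC2)C1c1c(O)ccc2ccccc12` is the starting point here. In a functional assay on Ehrlich cells (Mus musculus) for cytotoxicity, read by trypan blue exclusion, with a stated time of 2 h, tested at 100 ug/mL (a lower number here means a weaker effect, a higher number a stronger effect of the compound at the concentration tested), compound 2 gives 50%. The only neighbour with a measurement is compound 1 `N#CC1=C(N)N(c2ccc(S(N)(=O)=O)cc2)C2=C(CCCC2)C1c1ccc(Cl)c(Cl)c1`, which in this assay gives 50%, so compound 2 stands level with compound 1 at the digits shown. Going by the values given here, the one measured step, no change at the digits printed from compound 1 to compound 2 (within the scatter), exchanged one aromatic group for another on the same saturated ring carbon and left the read-out unchanged within the scatter.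

Compound 3 `N#CC1=C(N)N(c2ccc(S(N)(=O)=O)cc2)C2=C(CCCC2)C1c1cccs1` differs from compound 2 in the same place: thiophen-2-yl in place of 2-hydroxynaphthalen-1-yl on a saturated ring carbon. The change swaps a large two-ring aromatic group with a hydroxyl for a small five-membered aromatic ring containing sulfur. Since the earlier exchange of aromatic groups at this carbon produced no change beyond the scatter, the expected step of no change at the digits printed from compound 2 to compound 3 (within the scatter) is likewise none beyond the scatter. Compound 3 is therefore estimated at 50%, with a range from 30% to 70%.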

Compound 3, a percentage reported as activity, at one concentration (the size of the read-out at that concentration, not a potency): 20%
Beside the measured number, compound 3's estimate is 30 percentage points above it; the whole stated range lies above it.
By their numbers in this assay, from the lowest: compound 3; then compounds 1 and 2 (each within the scatter of the next).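

In this assay, the group on this saturated ring carbon turns out to matter: thiophen-2-yl gives a number 30 percentage points lower from compound 2 to compound 3 (beyond the scatter), and the same group gives a number 30 percentage points lower from compound 1 to compound 3 (beyond the scatter). The earlier pair alone made this position look indifferent to which aromatic group it carries, but these steps show that not every aromatic group is interchangeable here. No measurement shown here accounts for the lower number.

Thiophen-2-yl brings a five-membered ring and a sulfur atom together, so the compounds shown cannot separate the two or say which of them goes with the drop. As far as these compounds go, how a plain phenyl, a furan-2-yl ring or a non-aromatic group such as cyclohexyl would read on this carbon remains open.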